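The source may report more compounds than this note shows. Statements on the series, on what has been measured and on what is new or still open speak of the compounds shown alone.

Compound 3 `COc1ccc(Sc2nc3cc(N)cc(N)c3nc2-c2ccccc2)cc1` is known in a functional assay on MCF7 cells (Homo sapiens) for inhibition, read by sulforhodamine B assay, with a stated time of 48 h (on this read-out higher numbers stand for weaker inhibition of growth and lower numbers for stronger inhibition of growth), only as a limit, < 100000 nM, not as a measured number. Compound 2 `CCOC(=O)[C@H](CCC(=O)O)NC(=O)c1ccc(Oc2nc3cc(N)cc(N)c3nc2-c2ccccc2)cc1` likewise stands at a limit in this assay, < 100000 nM. Compound 1 `Nc1cc(N)c2nc(-c3ccccc3)c(NCc3ccc(Cl)c(Cl)c3)nc2c1`, which carries a different side group on the shared core, gives 53700 nM in this assay, a weak effect on growth. Compound 4 `Nc1cc(N)c2nc(-c3ccccc3)c(Sc3ccc(F)cc3)nc2c1` differs from compound 3 by a single change: fluoro in place of methoxy on an aromatic carbon. No measured step of this kind exists among these compounds, so there is no direct guide. The expected step is a step that the limit leaves unreadable from compound 3 to compound 4, no larger than the usual scatter. Compound 4 is therefore expected to give about 60000 nM in this assay, estimated to fall between 20000 nM and 100000 nM.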

Compound 4, concentration for total growth inhibition: 63100 nM
The estimate for compound 4 lay 1.1-fold (0.02 log units) below the measured number; the measured number falls inside the stated range.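

Among these compounds, no step from compound 3 to compound 4 can be read, because compound 3 is known only as a limit: the limit of < 100000 nM in this assay, at which 2 of the 4 values shown sit.

Whether fluoro in place of methoxy changes growth inhibition at all stays open in the compounds shown.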